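This account rests on a few compounds, and the source may have more. Where it says the series, first, only, none or still open, it means among the compounds named here.

Of the compounds shown here, three built on a shared core have been measured in a functional assay on L1210 cells (Mus musculus) for inhibition, read by MTT assay, with a stated time of 72 h; on this read-out lower numbers stand for stronger inhibition and higher numbers for weaker inhibition. Compound 2 `CN(C)c1ccc(/C=C2\CNC/C(=C\c3ccc(N(C)C)cc3)C2=O)cc1` gives 42500 nM. Compound 3 `CCN(CC)c1ccc2cc(/C=C3\CNC/C(=C\c4cc5ccc(N(CC)CC)cc5oc4=O)C3=O)c(=O)oc2c1` gives 29000 nM, which lies within the scatter of compound 2, so these two cannot be told apart. Compound 1 `O=C1/C(=C/c2cccc(O)c2)CNC/C1=C\c1cccc(O)c1` gives 2300 nM, a lower number that lies beyond the scatter from compound 2. Compound 2 therefore sits at the weak end of this small set, level with compound 3.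

Compound 4 `CN1C/C(=C\c2ccc(N(C)C)cc2)C(=O)/C(=C/c2ccc(N(C)C)cc2)C1` has not been measured yet. It differs from compound 2 in one place: methyl in place of hydrogen on an amine nitrogen in a ring, which is methyl in place of hydrogen on an amine nitrogen in a ring. For the measured compounds named here, no measured pair here shows a change at that nitrogen, so the data give no direct guide to the size of the step. The safest expectation is therefore no change beyond the scatter, with a slight lean toward a lower number. The estimated move is a 1.2-fold lower number from compound 2 to compound 4 (0.08 log units; within the scatter). Compound 4 is expected to read 35000 nM, with an estimated range from 10000 nM to 90000 nM.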

Compound 4, half-maximal inhibitory concentration: 28500 nM
Compound 4: middle estimate off by 1.2-fold (0.09 log units), on the high side, and the stated range covers the measured number.
By their numbers in this assay, from the lowest: compound 1; then compounds 4, 3 and 2 (each within the scatter of the next).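

In this assay, for the compounds shown here, methyl in place of hydrogen on the amine nitrogen in the ring gives a 1.5-fold lower number from compound 2 to compound 4 (0.17 log units; within the scatter) and this lies within the scatter, so this is the first direct sign that the change has no measurable effect here. For this pair, then, the nitrogen can carry one added carbon in place of its hydrogen without a change that can be told apart on this read-out. This is a single pair at the weak end of the set, and no outside measurement helps explain the result.

On these data alone, whether larger groups on this nitrogen, such as ethyl, benzyl or acetyl, would also leave the number unchanged remains open. So does whether the same methyl change would behave alike on compound 1, which carries different groups elsewhere.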